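Removing One Chloro from the Anilino Ring

The compounds below may be only part of what the source reports. "The series", "measured", "known", "first", "only" and "open" are said of these compounds alone.

Within the data shown here, the two compounds measured so far share one core and differ only in the aromatic ring attached to the amino nitrogen. Compound 1 `CN1CCN(CCCOc2cccc3nc(Nc4ccc(Cl)c(F)c4)ccc23)CC1` carries a 4-chloro-3-fluorophenyl group there, and in a functional assay on SK-MEL-28 cells (Homo sapiens) for inhibition, read by sulforhodamine B assay, with a stated time of 48 h (on this read-out lower numbers stand for stronger inhibition of growth and higher numbers for weaker inhibition of growth), compound 1 gives 1720 nM. Compound 2 `CN1CCN(CCCOc2cccc3nc(Nc4cc(Cl)cc(Cl)c4)ccc23)CC1` carries a 3,5-dichlorophenyl group instead, and in this assay compound 2 gives 1670 nM. The swap between them, a 1.0-fold lower number from compound 1 to compound 2 (0.01 log units; within the scatter), changes nothing that the assay can resolve, so compound 2 stands alongside compound 1 with an indistinguishable number.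

Compound 3 `CN1CCN(CCCOc2cccc3nc(Nc4cccc(Cl)c4)ccc23)CC1` takes the next step from compound 2: hydrogen in place of chloro on an aromatic carbon, on an aromatic carbon of a six-membered aromatic ring of carbon only, meta to the remaining chloro group and meta to a large group. Among the measured compounds shown here, no measured step removes a substituent from this ring, so the only guidance is that exchanging halogens on it, as in a 1.0-fold lower number from compound 1 to compound 2 (0.01 log units; within the scatter), left the number unchanged. A step of comparable size, or none beyond the scatter, is therefore expected, a 1.3-fold higher number from compound 2 to compound 3 (0.12 log units; within the scatter). For compound 3 the estimated value in this assay is 2200 nM, within a range of 900 nM to 5500 nM.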

Compound 3, concentration for 50% growth inhibition: 1650 nM
Compound 3: middle estimate off by 1.3-fold (0.12 log units), on the high side, and the stated range covers the measured number.
By their numbers in this assay, from the lowest: compounds 3, 2 and 1 (each within the scatter of the next).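

Among these compounds, this is the first measured step that takes a substituent off the anilino ring instead of exchanging one halogen pattern for another, and with hydrogen in place of chloro the result is a 1.0-fold lower number from compound 2 to compound 3 (0.01 log units; within the scatter) in this assay. The 3-chlorophenyl group also cannot be told apart from the 4-chloro-3-fluorophenyl group, with a 1.0-fold lower number from compound 1 to compound 3 (0.02 log units; within the scatter) between them, so across these three compounds a single chloro group on this ring gives the same reading as two halogens. Nothing available explains why the number holds steady through these changes to the ring.

From the compounds shown here alone, all three compounds keep a chloro group on this ring, so it remains open whether the ring needs any substituent at all, a question that a plain phenyl ring would answer. Going by these compounds, it is equally open whether groups of a different kind, such as methoxy, trifluoromethyl, an amine or a carboxylic acid, would leave the number where it is or finally move it beyond the scatter.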